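Swapping a Ring for a Branched Chain

The source may hold more compounds than are shown below. What is called first, only, known or untested is meant among the compounds shown, and "the series" means these compounds.

Compound 1 `CC(C)CC/N=C(\NC#N)Nc1cccnc1` and compound 2 `N#CN/C(=N\C1CCCCC1)Nc1cccnc1` were both tested in a functional assay on the whole organism (blood, strain Wistar-Okamoto) with Rattus norvegicus as the target, with a stated time of 5 days; on this read-out higher numbers stand for an effect only at larger amounts of compound and lower numbers for an effect already at smaller amounts. Compound 1 gives 20 mg/kg, and compound 2 gives 20 mg/kg; the step of no change at the digits printed from compound 1 to compound 2 (within the scatter) shows that the exchange of a ring for a chain of the same size left the dose unchanged. Compound 2 therefore stands level with compound 1. Compound 3 `CC(C)C(C)(C)/N=C(\NC#N)Nc1cccnc1` carries the change (1,1,2-trimethylpropyl in place of cyclohexyl on a double-bonded nitrogen). Among the compounds with values here, only that earlier step bears on it, and it lay within the scatter, so no step beyond the scatter is expected in this assay, no change at the digits printed from compound 2 to compound 3 (within the scatter). Compound 3 is thus estimated at 20 mg/kg, within 8 mg/kg to 50 mg/kg.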

Compound 3, minimum effective dose: 1 mg/kg
Compound 3: the middle estimate sits 20-fold (1.30 log units) above what was measured; measured number outside the range, below it.
By their numbers in this assay, from the lowest: compound 3; then compounds 1 and 2 (each within the scatter of the next).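

The place on the double-bonded nitrogen is clearly not indifferent: in this assay, 1,1,2-trimethylpropyl brings a 20-fold lower number from compound 2 to compound 3 (1.30 log units; beyond the scatter) and a 20-fold lower number from compound 1 to compound 3 (1.30 log units; beyond the scatter). Cyclohexyl and 1,1,2-trimethylpropyl both have 6 heavy atoms, all carbon, so the number of atoms alone does not set the dose here, and a ring is not needed for the lower number. Nothing measured here accounts for this drop. Still open, from the compounds shown here alone, is whether a tert-butyl group or a longer chain at this place would keep the dose this low, and how an amine on the chain would fare.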